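Sulfur-linked side chains on the shared core

The compounds below may be only part of what the source reports. "The series", "measured", "known", "first", "only" and "open" are said of these compounds alone.

Compound 2 `CC(C)c1n[nH]c2c(NCc3ccc(-c4ccccn4)cc3)nc(SC(CO)C(C)C)nc12` carries a 1-(hydroxymethyl)-2-methylpropyl on the sulfur of the shared core, and in a functional assay on HT cells (Homo sapiens) for antiproliferative activity, read by fluorescence, with a stated time of 72 h (a lower number here means a stronger inhibitor of growth, a higher number a weaker inhibitor of growth), compound 2 gives 980 nM, the highest of the three numbers measured. Compound 1 `CC(C)c1n[nH]c2c(NCc3ccc(-c4ccccn4)cc3)nc(SCC(O)CO)nc12` gives 21 nM and compound 3 `CC(C)c1n[nH]c2c(NCc3ccc(-c4ccccn4)cc3)nc(SC(C)C(C)O)nc12` gives 190 nM in this assay. The step of a 47-fold higher number from compound 1 to compound 2 (1.67 log units; beyond the scatter) and the step of a 5.2-fold lower number from compound 2 to compound 3 (0.71 log units; beyond the scatter) both leave compound 2 at the weak end of the set, while the step of a 9.0-fold higher number from compound 1 to compound 3 (0.96 log units; beyond the scatter) places the 2,3-dihydroxypropyl chain ahead of the other two measured side chains.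

Compound 4 `CC(C)c1n[nH]c2c(NCc3ccc(-c4ccccn4)cc3)nc(SC[C@H](O)CN)nc12` has not yet been measured. Its change from compound 2 reads (3-amino-2-hydroxypropyl in place of 1-(hydroxymethyl)-2-methylpropyl on a sulfur). The entering 3-amino-2-hydroxypropyl chain resembles the 2,3-dihydroxypropyl of compound 1 more closely than any other chain measured, so the large step from compound 1 to compound 2 bears most on this case, read in reverse; the modest step from compound 3 to compound 2 points the same way. A large downward step is therefore expected in this assay, the expected step being a 25-fold lower number from compound 2 to compound 4 (1.39 log units; beyond the scatter). Going by the values given here, no measured compound carries an amine on this chain, which widens the range. Compound 4 is expected at 40 nM, within 10 nM to 160 nM.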

Compound 4, concentration for 50% growth inhibition: 63 nM
Compound 4: the middle estimate sits 1.6-fold (0.20 log units) below what was measured; the measured number falls inside the stated range.
By their numbers in this assay, from the lowest: compound 1; then compound 4; then compound 3; then compound 2.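

At this sulfur, in this assay, a chain carrying an amine sits well clear of the weak end of the set, with a 16-fold lower number from compound 2 to compound 4 (1.19 log units; beyond the scatter) as the step from the 1-(hydroxymethyl)-2-methylpropyl chain. The same chain also improves on the 2-hydroxy-1-methylpropyl chain, with a 3.0-fold lower number from compound 3 to compound 4 (0.48 log units; beyond the scatter) printed beyond the scatter, so the order of the side chains now has a fourth point in its upper half. Replacing the 1,2-dihydroxyethyl on a saturated chain carbon bound to a sulfur with 2-amino-1-hydroxyethyl is not neutral, since a 3.0-fold higher number from compound 1 to compound 4 (0.48 log units; beyond the scatter) leaves the 2,3-dihydroxypropyl chain of compound 1 ahead of the new chain.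

The compounds shown leave open whether a carboxylic acid, a dimethylamine or a longer chain ending in an amine would hold this number at the sulfur, and whether the opposite configuration at the defined stereocentre of compound 4 would read differently. No supporting data bear on why the 3-amino-2-hydroxypropyl chain falls where it does in this order.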